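Pyrrolidine to piperidine on the aminopropoxy chain

This account rests on a few compounds, and the source may have more. Where it says the series, first, only, none or still open, it means among the compounds named here.

Compound 1 `COc1ccc(-c2cc3ccc(OC)cc3c(=O)n2-c2ccc(OCCCN3CCCCC3)cc2)cc1` was tested in a functional assay on MCF7 cells (Homo sapiens) for antiproliferative activity, read by MTT assay, with a stated time of 48 h (on this read-out higher numbers stand for weaker inhibition and lower numbers for stronger inhibition), and returned only a limit, > 1000000 nM. Among the compounds with values here, compound 2 `O=c1c2cc(O)ccc2cc(-c2ccc(O)cc2)n1-c1ccc(OCCCN2CCCC2)cc1` supplies the sole number in this assay, 12700 nM. Compound 3 `O=c1c2cc(O)ccc2cc(-c2ccc(O)cc2)n1-c1ccc(OCCCN2CCCCC2)cc1` differs from compound 2 by piperidin-1-yl in place of pyrrolidin-1-yl on a saturated chain carbon, three bonds along the chain from an oxygen on an aromatic ring. Within the data shown here, no step between measured compounds is available to guide this change, so the expectation rests on the change alone: the step from compound 2 to compound 3 in this assay is expected to be a 1.3-fold lower number from compound 2 to compound 3 (0.10 log units; within the scatter), nothing beyond the usual scatter. In this assay compound 3 is estimated at 10000 nM, within 4000 nM to 25000 nM.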

Compound 3, half-maximal inhibitory concentration: 2730 nM
Estimate against measurement, compound 3: 3.7-fold (0.56 log units) above; the whole stated range lies above it.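

Within the data shown here, this is the first readable step at this position, and it shows that ring size at the end of the chain is enough to move the number: in this assay, piperidin-1-yl in place of pyrrolidin-1-yl gives a 4.7-fold lower number from compound 2 to compound 3 (0.67 log units; beyond the scatter). The step rests on this single pair, on the core shared by compound 2 and compound 3. No measurement shown explains why the six-membered ring differs from the five-membered one.

As far as these compounds go, whether morpholin-4-yl, dimethylamino or a longer chain would shift the number further remains open. So does whether the same change would matter on the core of compound 1.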